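Growth inhibition in a tricyclic diterpenoid–indole series

This account rests on a few compounds, and the source may have more. Where it says the series, first, only, none or still open, it means among the compounds named here.

Measured compounds:
- compound 1, `COC(=O)[C@@]1(C)CCC=C2[C@@H]1CC[C@@H](C)[C@]2(C)Cc1c[nH]c2ccc(OC)cc12`: 1300 nM
- compound 2, `COC(=O)[C@@]1(C)CCC=C2[C@@H]1CC[C@@H](C)[C@]2(C)Cc1c[nH]c2ccc(C(F)(F)F)cc12`: 14000 nM
- compound 3, `COC(=O)[C@@]1(C)CCC=C2[C@@H]1CC[C@@H](C)[C@]2(C)Cc1c(C)[nH]c2ccc(OC)cc12`: 15000 nM

All three were run in a functional assay on SW1573 cells (Homo sapiens) for inhibition, read by sulforhodamine B assay, with a stated time of 48 h; on this read-out lower numbers stand for stronger inhibition of growth and higher numbers for weaker inhibition of growth. Compound 1 gives the lowest number of the three, with 1300 nM. Two single changes from it have been measured, and both move the number in the same direction. The first, (trifluoromethyl in place of methoxy on an aromatic carbon), gives an 11-fold higher number from compound 1 to compound 2 (1.03 log units; beyond the scatter). The second, (methyl in place of hydrogen on an aromatic carbon), gives a 12-fold higher number from compound 1 to compound 3 (1.06 log units; beyond the scatter). Compound 2 and compound 3 stand within the scatter of each other in this assay, so no order between them can be read from these numbers.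

Compound 4, `COC(=O)[C@@]1(C)CCC=C2[C@@H]1CC[C@@H](C)[C@]2(C)Cc1c(C)[nH]c2ccc(C(F)(F)F)cc12`, has not yet been measured. It stands to compound 3 as compound 2 stands to compound 1: the change is trifluoromethyl in place of methoxy on an aromatic carbon, and the surrounding place is the same in both cases, so this is the same change, made for the second time in the series. The two cores differ by methyl in place of hydrogen on an aromatic carbon.

For the measured compounds named here, for compound 4 the working expectation is a step of about the same size as the one seen before, that is a 5.3-fold higher number from compound 3 to compound 4 (0.73 log units; beyond the scatter), because the only precedent is an 11-fold higher number from compound 1 to compound 2 (1.03 log units; beyond the scatter). Whether that step carries over unchanged onto the core of compound 3 is not known from these data, and compound 3 already gives 15000 nM, so the number expected for compound 4 would lie well beyond anything measured so far in this series. The estimated value for compound 4 in this assay is 80000 nM, expected to fall between 20000 nM and 250000 nM.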

Compound 4, concentration for 50% growth inhibition: 15000 nM
Compound 4: middle estimate off by 5.3-fold (0.73 log units), on the high side; measured number below the stated range.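

In this assay, trifluoromethyl in place of methoxy on an aromatic carbon gives no change at the digits printed from compound 3 to compound 4 (within the scatter), so the step seen on the core of compound 1 does not carry over to the core of compound 3: the same change on two cores in this assay, an 11-fold higher number (1.03 log units; beyond the scatter) from compound 1 to compound 2 and no change at the digits printed (within the scatter) from compound 3 to compound 4, 11-fold (1.03 log units) apart, beyond the scatter of two such steps. The same holds when the comparison is read through the other change, since methyl in place of hydrogen on an aromatic carbon gives a 1.1-fold higher number from compound 2 to compound 4 (0.03 log units; within the scatter), and this step also differs between the two cores: the same change on two cores in this assay, a 12-fold higher number (1.06 log units; beyond the scatter) from compound 1 to compound 3 and a 1.1-fold higher number (0.03 log units; within the scatter) from compound 2 to compound 4, 11-fold (1.03 log units) apart, beyond the scatter of two such steps. In this series, then, the size of each step depends on the core that carries it, so a step read on one of these cores cannot be transferred to the other, but these four compounds form a single set of paired changes and do not show why the steps differ or how either change would behave on any further core.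

Still open, going by these compounds, is whether compound 2, compound 3 and compound 4 stand within the scatter of one another by coincidence or whether other changes on the methyl-bearing core would also leave the number unmoved. A nitrile or a chlorine in place of the trifluoromethyl, an ethyl in place of the added methyl, or a carboxylic acid in place of the methyl ester would each test this further.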